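Capping the Pyrrolidine Nitrogen of Compound 1

The compounds below may be only part of what the source reports. "The series", "measured", "known", "first", "only" and "open" are said of these compounds alone.

Compound 1 `CN1CCN(c2ccc(Nc3ncc4nc(Nc5ccccc5)n([C@@H]5CCNC5)c4n3)cc2)CC1`: 65 nM
Compound 2 `CN1CCN(c2ccc(Nc3ncc4nc(Nc5ccc(F)cc5)n([C@@H]5CCNC5)c4n3)cc2)CC1`: 300 nM

Among the measured compounds shown here, in a functional assay on HCC827 cells (Homo sapiens) for antiproliferative activity, read by MTT assay, with a stated time of 72 h (on this read-out lower numbers stand for stronger inhibition and higher numbers for weaker inhibition), compound 1 has the lowest of the two numbers measured; the only other compound, compound 2, sits a 4.6-fold higher number from compound 1 to compound 2 (0.66 log units; beyond the scatter) away. That step puts a fluoro in place of hydrogen on an aromatic carbon, so it concerns a different part of the molecule and does not speak to the change considered here. Compound 3 `CNC(=O)CN1CC[C@H](n2c(Nc3ccccc3)nc3cnc(Nc4ccc(N5CCN(C)CC5)cc4)nc32)C1` differs from compound 1 in one place: 1-((methylcarbamoyl)methyl)pyrrolidin-3-yl in place of pyrrolidin-3-yl on an aromatic nitrogen. For the measured compounds named here, no measured pair shows what adding such a chain to the pyrrolidine nitrogen does, so no step beyond the scatter is expected in this assay in either direction. Compound 3 is therefore expected to give about 80 nM, within a range of 30 nM to 250 nM. This estimate means a 1.2-fold higher number from compound 1 to compound 3 (0.09 log units; within the scatter), a change expected to stay within the scatter.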

Compound 3, half-maximal inhibitory concentration: 170 nM
For compound 3 the middle estimate is 2.1-fold (0.33 log units) below the measured one; low and high end bracket the measured number.
By their numbers in this assay, from the lowest: compound 1; then compounds 3 and 2 (each within the scatter of the next).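

Among the compounds shown here, compound 3 is the first compound here changed at the pyrrolidine nitrogen, since the step from compound 1 to compound 2 concerned only the anilino group. In this assay, replacing pyrrolidin-3-yl with 1-((methylcarbamoyl)methyl)pyrrolidin-3-yl gives a 2.6-fold higher number from compound 1 to compound 3 (0.42 log units; beyond the scatter), so this added chain weakens inhibition modestly but does not abolish it, and a free hydrogen on that nitrogen is not essential for activity in these cells. Nothing available explains why the number rises.

As far as these compounds go, it remains open whether the weakening comes from simply capping the nitrogen or from this particular chain. A plain methyl, an acetyl group, a chain ending in a carboxylic acid or an amine, or a longer chain with the same amide at its end could help separate these possibilities.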